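Six-Membered Ring in Place of Five on the Core

The source may report more compounds than this note shows. Statements on the series, on what has been measured and on what is new or still open speak of the compounds shown alone.

Compound 3 `CCCCCCCCCCc1ccc(-c2noc([C@@H]3CC[C@H](N)C3)n2)cc1` gives 38% in an assay on HeLa cells for inhibition of sphingosine-1-phosphate transporter SPNS2 (Mus musculus), read by LC-MS, tested at 2 uM (on this read-out lower numbers stand for less inhibition and higher numbers for more inhibition at the one concentration tested (going by the name of the read-out)), the highest of the three numbers measured. Compound 1 `CCCCCCCCCCc1ccc(-c2noc([C@H]3CCCN3)n2)cc1` gives 12% in this assay, and compound 2 `CCCCCCCCCCc1ccc(-c2noc(CN3CCNCC3)n2)cc1` gives 19%. The steps of a number 26 percentage points higher from compound 1 to compound 3 (beyond the scatter) and a number 19 percentage points higher from compound 2 to compound 3 (beyond the scatter) both lie beyond the scatter, whereas a number 7 percentage points higher from compound 1 to compound 2 (within the scatter). Compound 4 `CCCCCCCCCCc1ccc(-c2noc([C@H]3CCC[C@@H](N)C3)n2)cc1` carries 3-aminocyclohexyl in place of 3-aminocyclopentyl on an aromatic carbon. Going by the values given here, no measured step bears directly on this exchange; the two steps leading to compound 3 concern a different group on the aromatic carbon, not the size of the ring, and both were modest. The step of a number 2 percentage points higher from compound 3 to compound 4 (within the scatter) is therefore expected to remain within the scatter. Compound 4 is estimated at 40%, with a range from 20% to 60%.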

Compound 4, a percentage reported as inhibition, at one concentration (the size of the read-out at that concentration, not a potency): 29%
The estimate for compound 4 lay 11 percentage points above the measured number, and the stated range covers the measured number.
By their numbers in this assay, from the lowest: compounds 1, 2, 4 and 3 (each within the scatter of the next, the first and the last beyond it).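

At this position, on the five-membered aromatic ring, 3-aminocyclohexyl and 3-aminocyclopentyl are not told apart in this assay, since the exchange gives a number 9 percentage points lower from compound 3 to compound 4 (within the scatter) and a ring of either size remains compatible with the number. Against the other two groups the six-membered ring separates less clearly than compound 3 did, with a number 17 percentage points higher from compound 1 to compound 4 (beyond the scatter) but only a number 10 percentage points higher from compound 2 to compound 4 (within the scatter). Nothing available explains these numbers.

From the compounds shown here alone, whether a hydroxyl or a carboxylic acid in place of the amine on the cyclohexyl ring would hold the number stays open.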